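The source may hold more compounds than are shown below. What is called first, only, known or untested is meant among the compounds shown, and "the series" means these compounds.

Compound 1 `CO/N=C(\C)COc1ccc2oc(-c3ccccc3)cc(=O)c2c1` and compound 2 `CO/N=C(\C)COc1ccc2c(=O)cc(-c3ccccc3)oc2c1` are built from the same atoms joined differently; the difference between the two cores is not broken down here. In a functional assay on SK-HEP1 cells (Homo sapiens) for antiproliferative activity (a higher number here means a weaker inhibitor of growth, a lower number a stronger inhibitor of growth), compound 1 gives 800000 nM, while compound 2 gives 2000000 nM, the highest of the three measured numbers, and its gaps to both other compounds lie beyond the scatter. Compound 3 `O=c1cc(-c2ccccc2)oc2ccc(OC/C(=N/O)c3ccccc3)cc12` comes from compound 1 by a group of 9 heavy atoms (7 carbon, 1 nitrogen, 1 oxygen; one six-membered aromatic ring of carbon only) in place of a group of 5 heavy atoms (3 carbon, 1 nitrogen, 1 oxygen; no ring), on a saturated chain carbon bound to an oxygen on an aromatic ring. In this assay compound 3 gives 700000 nM, so the step of a 1.1-fold lower number from compound 1 to compound 3 (0.06 log units; within the scatter) stays within the scatter and shows no change. Compound 4 `O=c1cc(-c2ccccc2)oc2cc(OC/C(=N/O)c3ccccc3)ccc12` comes from compound 2 by the same change, (a group of 9 heavy atoms (7 carbon, 1 nitrogen, 1 oxygen; one six-membered aromatic ring of carbon only) in place of a group of 5 heavy atoms (3 carbon, 1 nitrogen, 1 oxygen; no ring), on a saturated chain carbon bound to an oxygen on an aromatic ring), made at the same place, but on the core of compound 2 rather than that of compound 1. Within the data shown here, the step from compound 2 to compound 4 in this assay is expected to be small, a 1.1-fold lower number from compound 2 to compound 4 (0.05 log units; within the scatter), because the one measured instance of this change, a 1.1-fold lower number from compound 1 to compound 3 (0.06 log units; within the scatter), stayed within the scatter. Compound 4 is therefore estimated at 1800000 nM, with a likely range from 700000 nM to 4500000 nM.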

Compound 4, concentration for 50% growth inhibition: 2000000 nM
Estimate against measurement, compound 4: 1.1-fold (0.05 log units) below; measured number inside the range.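

In this assay, putting the group with the six-membered aromatic ring in place of the smaller ring-free group gives no change at the digits printed from compound 2 to compound 4 (within the scatter), and the change reads alike on the two cores: the same change on two cores in this assay, a 1.1-fold lower number (0.06 log units; within the scatter) from compound 1 to compound 3 and no change at the digits printed (within the scatter) from compound 2 to compound 4, 1.1-fold (0.06 log units) apart, within the scatter of two such steps

Among these compounds, this shows only that a change with no detectable effect on one core also has none on the other; since neither step lies beyond the scatter, it does not show that a change that moves the number would carry across these cores in the same way. The entering group also differs from the leaving group in both its aromatic ring and its hydrogen-bond donor, so these two compounds pairs cannot separate the two differences.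

On these data alone, it remains open whether an amine, a carboxylic acid or a longer chain on the saturated chain carbon bound to an oxygen on an aromatic ring would shift the number on either core. Also open, as far as these compounds go, is whether any such shift would be the same size on both cores.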